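Replacing oxan-4-yl with phenyl in compound 1

The source may report more compounds than this note shows. Statements on the series, on what has been measured and on what is new or still open speak of the compounds shown alone.

compound 1 (`O=C(C1CC2(CCN(C3CCOCC3)CC2)C1)N1CCN(C2CCC2)CC1`) with "not determined" (no result reported)
compound 2 (`O=C(C1CC2(CCN(C3CCOCC3)CC2)C1)N1CCN(C2CCCCC2)CC1`) with 0.75
compound 3 (`CC(C)N1CCN(C(=O)C2CC3(CCN(C4CCOCC4)CC3)C2)CC1`) with -0.74

These are the results so far in a physicochemical assay for lipophilicity, read by HPLC, using the shake flask method, measured as octanol-water partition (a higher number here means a more lipophilic compound, a lower number a more polar compound), for three compounds that share a core. Compound 1 has no number of its own, so the account of it has no measured starting point. The nearest figures are those of compound 2 at 0.75 and compound 3 at -0.74 and neither can be read as a value for compound 1.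

The next compound to be measured is compound 4 (`O=C(C1CC2(CCN(c3ccccc3)CC2)C1)N1CCN(C2CCC2)CC1`). It differs from compound 1 by phenyl in place of oxan-4-yl on an amine nitrogen in a ring with phenyl in place of oxan-4-yl on an amine nitrogen in a ring.

For the measured compounds named here, no measured step covers this exchange. Going by the values given here, the only one available is a number 1.49 log units lower from compound 2 to compound 3 (beyond the scatter) and it concerns isopropyl in place of cyclohexyl on a different amine nitrogen. It therefore bears on the case only indirectly, by showing that exchanging one group on an amine nitrogen in a ring can move the distribution coefficient a long way in this series. On that basis, a large step upward in this assay is expected from compound 1 to the new compound, though with wide uncertainty given the missing starting value. For compound 4 the estimated value is 1.6 with an expected range from 0.8 to 2.4 in this assay.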

Compound 4, distribution coefficient: 3.25
Compound 4: the middle estimate sits 1.65 log units below what was measured; measured number outside the range, above it.
By their numbers in this assay, from the lowest: compound 3; then compound 2; then compound 4.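

In this assay, for the compounds shown here, compound 4 stands at 3.25 while compound 1 reads "not determined" (no result reported), so no step from compound 1 to compound 4 can be read. Nothing available offers an explanation for this result. The compounds shown leave open how far phenyl in place of oxan-4-yl moves the distribution coefficient on the shared core.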